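This account rests on a few compounds, and the source may have more. Where it says the series, first, only, none or still open, it means among the compounds named here.

Compound 1 `Cc1ccccc1NC1=C/C(=N/NC(N)=S)C(=O)N=C1Nc1ccccc1C` and compound 2 `NC(=S)N/N=C1/C=C(Nc2ccc(F)cc2)C(Nc2ccc(F)cc2)=NC1=O` carry the same group on a double-bonded nitrogen, but the difference between their two cores is not broken down here. In a functional assay on MCF7 cells (Homo sapiens) for antiproliferative activity, read by MTT assay, with a stated time of 72 h (on this read-out lower numbers stand for stronger inhibition and higher numbers for weaker inhibition), compound 1 gives 580 nM, and in this assay compound 2 gives 1120 nM; these two numbers lie within the scatter of each other, so no order between them can be read. Compound 3 `Cc1ccccc1NC1=C/C(=N/N=C(\N)SCc2ccccc2)C(=O)N=C1Nc1ccccc1C` arises from compound 1 through (a group of 11 heavy atoms (8 carbon, 2 nitrogen, 1 sulfur; one six-membered aromatic ring of carbon only) in place of a group of 4 heavy atoms (1 carbon, 2 nitrogen, 1 sulfur; no ring), on a double-bonded nitrogen), and in this assay compound 3 gives 16300 nM. That single change produced a 28-fold higher number from compound 1 to compound 3 (1.45 log units; beyond the scatter), a large loss of potency. Compound 4 `N/C(=N\N=C1\C=C(Nc2ccc(F)cc2)C(Nc2ccc(F)cc2)=NC1=O)SCc1ccccc1` is the counterpart built from compound 2 by the same change, (a group of 11 heavy atoms (8 carbon, 2 nitrogen, 1 sulfur; one six-membered aromatic ring of carbon only) in place of a group of 4 heavy atoms (1 carbon, 2 nitrogen, 1 sulfur; no ring), on a double-bonded nitrogen), at a place described in identical words in both pairs. Going by the values given here, only one precedent exists for this change, so the expectation rests on it alone. Because that precedent gave a 28-fold higher number from compound 1 to compound 3 (1.45 log units; beyond the scatter), the step is expected to be a 22-fold higher number from compound 2 to compound 4 (1.35 log units; beyond the scatter). In this assay compound 4 is therefore estimated at 25000 nM, with a plausible range from 8000 nM to 80000 nM.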

Compound 4, half-maximal inhibitory concentration: 7580 nM
Compound 4: the middle estimate sits 3.3-fold (0.52 log units) above what was measured, outside the stated range (below it).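

In this assay the change again gives a higher number, a 6.8-fold higher number from compound 2 to compound 4 (0.83 log units; beyond the scatter), so the direction of the step carries over from one core to the other. The size of the step does not carry over, and the two steps stand clearly apart: the same change on two cores in this assay, a 28-fold higher number (1.45 log units; beyond the scatter) from compound 1 to compound 3 and a 6.8-fold higher number (0.83 log units; beyond the scatter) from compound 2 to compound 4, 4.2-fold (0.62 log units) apart, beyond the scatter of two such steps. Going by these compounds alone, this shows that a figure taken from one core is a poor guide to the size of the step on the other, although the loss of potency recurs on both; with only two pairs, it does not show which feature of the cores goes with the gap, nor how the change would behave on a third core.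

The compounds shown leave open whether a methyl or an ethyl chain, entering in place of the group of 11 heavy atoms, would bring a step of similar size. Equally open, going by these compounds, is how the same change would run on a core bearing an amine or a carboxylic acid.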